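Removing the ethyl from compound 2's ring nitrogen

The compounds below may be only part of what the source reports. "The series", "measured", "known", "first", "only" and "open" are said of these compounds alone.

Of the compounds shown here, three share a core and have been measured in a functional assay (spleen, spleen) for activation, with Mus musculus as the target; a lower number here means that less compound is needed, a higher number that more compound is needed for the effect. Going by the values given here, compound 1 `COc1ccc(Cn2c(O)nc3c(N)ncnc32)cc1` gives 10 uM, and compound 3 `Cc1ccc(Cn2c(O)nc3c(N)ncnc32)cc1` gives 10 uM; the only one-place step among the measured compounds, no change at the digits printed from compound 1 to compound 3 (within the scatter), stays within the scatter. Compound 2 `CCNc1nc(N)c2nc(O)n(Cc3ccccc3)c2n1` gives 1 uM, the lowest of the three numbers, and its gap to both compound 1 and compound 3 lies beyond the scatter.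

Compound 4 `Nc1nc(N)c2nc(O)n(Cc3ccccc3)c2n1` differs from compound 2 in one place: hydrogen in place of ethyl on a nitrogen on an aromatic ring. Among the compounds with values here, no measured step touches this nitrogen, so the expectation rests on the wider picture alone. Compound 1 and compound 3, which carry a hydrogen where compound 2 carries the ethylamino group and also differ in the benzyl substituent, sit at higher numbers; compound 4 keeps the amino group but loses the ethyl, so a number between compound 2 and those two is estimated.

In this assay compound 4 is therefore expected to give about 3 uM, within 1 uM to 10 uM, which would mean a step of a 3.0-fold higher number from compound 2 to compound 4 (0.48 log units; beyond the scatter).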

Compound 4, minimum effective concentration: 10 uM
Beside the measured number, compound 4's estimate is 3.3-fold (0.52 log units) below it, and the stated range covers the measured number.
By their numbers in this assay, from the lowest: compound 2; then compounds 1, 3 and 4 (each within the scatter of the next).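

Going by these compounds alone, until this pair, no step touched the nitrogen on an aromatic ring that carries the ethyl, and the only one-place step available, a change of methoxy to methyl on an aromatic carbon, stayed within the scatter. In this assay, within the data shown here, changing ethylamino to amino gives a 10-fold higher number from compound 2 to compound 4 (1.00 log units; beyond the scatter) and so provides the first one-place step beyond the scatter, showing that the number responds to what sits on this nitrogen. With ethyl present less compound is needed for the effect than with hydrogen, although this rests on one pair, and nothing on hand accounts for the difference.

The compounds shown give only the two end points of hydrogen and ethyl at this nitrogen, so it remains open whether methyl, a longer chain such as propyl or butyl, or a ring such as cyclopropyl would lower the number further or raise it again. As far as these compounds go, it is also open whether ethyl would bring a similar step with methoxy or methyl on the benzyl ring, since this pair carries an unsubstituted benzyl group.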